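A few compounds are considered here, and "the series" means these few. Any claim that something is new, unique, unknown or untested is made for them only; others in the source may bear on it.

Measured compounds in an ADME assay on MT2 cells (Homo sapiens) for cytotoxicity, read by XTT assay, with a stated time of 4 days; a higher number here means that more compound is tolerated, a lower number that less compound is tolerated:

Compound 1, `Cc1cc(/C=C2\SC(=S)N(c3ccccc3)C2=O)c(C)n1-c1ccc(O)c(C(=O)O)c1`: compound 1 gives > 100000 nM, which is a limit of the assay and not a number.
Compound 2, `Cc1cc(/C=C2\SC(=S)N(Cc3ccccc3)C2=O)c(C)n1-c1ccc(O)c(C(=O)O)c1`: compound 2 gives 159000 nM.
Compound 3, `Cc1cc(/C=C2\SC(=S)N(Cc3ccc(Br)cc3)C2=O)c(C)n1-c1ccc(O)c(C(=O)O)c1`: compound 3 gives 94400 nM.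

Compound 3 holds the lowest of the two numbers read in this assay; its nearest neighbour is compound 2, and that gap, a 1.7-fold lower number from compound 2 to compound 3 (0.23 log units; within the scatter), lies within the scatter. Compound 1 sits at the limit noted in the limit of > 100000 nM in this assay, at which 1 of the 3 values shown sits, so the step that the limit leaves unreadable from compound 1 to compound 2 cannot be read, and an at least 1.0-fold lower number from compound 1 to compound 3 (0.02 log units; that floor lies within the scatter) gives only a floor within the scatter. All three values thus sit in one band, with no step beyond the scatter anywhere in the series.

Compound 4, `COc1ccc(CN2C(=O)/C(=C/c3cc(C)n(-c4ccc(O)c(C(=O)O)c4)c3C)SC2=S)cc1`, differs from compound 3 by methoxy in place of bromo on an aromatic carbon. Among the measured compounds shown here, the only measured step touching that same aromatic carbon is a 1.7-fold lower number from compound 2 to compound 3 (0.23 log units; within the scatter), which stayed within the scatter; no measured step covers methoxy. The step from compound 3 to compound 4 in this assay is therefore expected to be a 1.3-fold higher number from compound 3 to compound 4 (0.10 log units; within the scatter), nothing beyond the scatter. Compound 4 is estimated at 120000 nM, between 60000 nM and 250000 nM, with a fair chance that only a limit is reported.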

Compound 4, half-maximal cytotoxic concentration: 75300 nM
Estimate against measurement, compound 4: 1.6-fold (0.20 log units) above, and the stated range covers the measured number.
By their numbers in this assay, from the lowest: compounds 4, 3 and 2 (each within the scatter of the next, the first and the last beyond it).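

In this assay, methoxy in place of bromo on the aromatic carbon para to a large group gives a 1.3-fold lower number from compound 3 to compound 4 (0.10 log units; within the scatter), so the two groups cannot be told apart at this position. Measured against the unsubstituted benzyl, methoxy gives a 2.1-fold lower number from compound 2 to compound 4 (0.32 log units; beyond the scatter), the only step shown that lies beyond the scatter, and it is a modest one. Against the phenyl group on the amide-type nitrogen, only a floor can be read, an at least 1.3-fold lower number from compound 1 to compound 4 (0.12 log units; that floor lies within the scatter), and the value behind it is a limit and not a number: the limit of > 100000 nM in this assay, at which 1 of the 4 values shown sits.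

Still open, as far as these compounds go, is whether an amine or a nitrile on this aromatic carbon would stay in the same band in this assay. The same question holds for a longer chain in place of the benzyl group on the amide-type nitrogen.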